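Working notes: the step from compound 3 to compound 4

The compounds below may be only part of what the source reports. "The series", "measured", "known", "first", "only" and "open" are said of these compounds alone.

Measured in a physicochemical assay for solubility, in phosphate buffer, measured as kinetic solubility, with a stated time of 24 h, at pH 6.5; a lower number here means a less soluble compound, a higher number a more soluble compound:
- compound 1 (`CC(C)Oc1cc(Oc2ccc(S(C)(=O)=O)cc2)cc(-c2cccc(=O)[nH]2)c1`): 11000 nM
- compound 2 (`CC(C)Oc1cc(Oc2ccc(S(C)(=O)=O)cc2)cc(-c2nccc(=O)[nH]2)c1`): 25000 nM
- compound 3 (`Cc1cnc(-c2cc(Oc3ccc(S(C)(=O)=O)cc3)cc(OC(C)C)c2)[nH]c1=O`): 1900 nM

Compound 3 stands lowest of the three numbers. Compound 4 (`Cc1cc(=O)[nH]c(-c2cc(Oc3ccc(S(C)(=O)=O)cc3)cc(OC(C)C)c2)n1`) is the next to be read, and its difference from compound 3 is this: (a group of 8 heavy atoms (5 carbon, 2 nitrogen, 1 oxygen; one six-membered aromatic ring with 2 hetero atoms) in place of a group of 8 heavy atoms (5 carbon, 2 nitrogen, 1 oxygen; one six-membered aromatic ring with 2 hetero atoms), on an aromatic carbon). The two have the same atoms, joined differently, and the exchanged group sits on an aromatic carbon of a six-membered aromatic ring of carbon only.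

Within the data shown here, three measured steps bear on this change. The closest, a 13-fold lower number from compound 2 to compound 3 (1.12 log units; beyond the scatter) with methyl in place of hydrogen on an aromatic carbon, is large. The other two, a 2.3-fold higher number from compound 1 to compound 2 (0.36 log units; beyond the scatter) and a 5.8-fold lower number from compound 1 to compound 3 (0.76 log units; beyond the scatter) in turn, are modest and run in opposite directions, so exchanges at this place have moved the number both ways. Among the measured compounds shown here, no measured compound shows whether the low number of compound 3 depends on how these atoms are joined. A modest rise is therefore expected, no larger than the large step, though a result without change would not surprise. The expected change is a 2.9-fold higher number from compound 3 to compound 4 (0.46 log units; beyond the scatter) in this assay as an estimate with wide uncertainty. Compound 4 is estimated at 5500 nM (expected range 1500 nM to 22000 nM).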

Compound 4, solubility: 15000 nM
The estimate for compound 4 lay 2.7-fold (0.44 log units) below the measured number; low and high end bracket the measured number.
By their numbers in this assay, from the lowest: compound 3; then compounds 1, 4 and 2 (each within the scatter of the next, the first and the last beyond it).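

Joining the same atoms differently is enough to move the number in this assay by a wide margin, with a 7.9-fold higher number from compound 3 to compound 4 (0.90 log units; beyond the scatter), so the low number of compound 3 is not set by the atom count of the exchanged group alone. Methyl in place of hydrogen now has two outcomes at this place: a 1.7-fold lower number from compound 2 to compound 4 (0.22 log units; within the scatter) stands against the large 13-fold lower number from compound 2 to compound 3 (1.12 log units; beyond the scatter), which leaves compound 3 as the one member that breaks from the others, while a 1.4-fold higher number from compound 1 to compound 4 (0.13 log units; within the scatter) also stays within the scatter. Nothing available gives a reason for the gap between the two isomers.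

Still open, going by these compounds, is whether an ethyl, a methoxy or an amine in place of the methyl would follow compound 3 or compound 4 in this assay when set on the same ring atoms. Also open, on these data alone, is whether the gap between these two isomers survives when the isopropoxy group gives way to a longer chain or a carboxylic acid elsewhere on the shared core.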